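Removing the bromo group from compound 2

This account rests on a few compounds, and the source may have more. Where it says the series, first, only, none or still open, it means among the compounds named here.

compound 1 `COc1ccc(CN(C(=O)CSC(=S)N2CCN(C(=O)OC(C)(C)C)CC2)c2ccc(Cl)cc2)cc1` gives > 20000 nM in a functional assay on KYSE-450 cells (Homo sapiens) for inhibition, read by CCK-8 assay, with a stated time of 48 h; on this read-out lower numbers stand for stronger inhibition and higher numbers for weaker inhibition
compound 2 `COc1ccc(CN(C(=O)CSC(=S)N2CCN(C(=O)OC(C)(C)C)CC2)c2ccc(Br)cc2)cc1` gives > 20000 nM in this assay

Compound 2 stands at > 20000 nM as a limit, not a number. Compound 1 also reads only as a limit, and the limit of > 20000 nM in this assay, at which 2 of the 2 values shown sit, is all that the series shows so far. The next compound is compound 3 `COc1ccc(CN(C(=O)CSC(=S)N2CCN(C(=O)OC(C)(C)C)CC2)c2ccccc2)cc1`, which differs from compound 2 by hydrogen in place of bromo on an aromatic carbon in one change, hydrogen in place of bromo on an aromatic carbon, para to a large group. Among the measured compounds shown here, the one measured step bearing on this is a step that the two limits leave unreadable from compound 1 to compound 2 with bromo in place of chloro on an aromatic carbon. That step offers no size to carry over, so no readable step and no direction is expected in this assay for this change. The expected step is a step that the limit leaves unreadable from compound 2 to compound 3 by this estimate, and a reading given only as a limit is likely. For compound 3 the estimate is 25000 nM with an expected range from 12000 nM to 60000 nM in all.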

Compound 3, half-maximal inhibitory concentration: > 20000 nM
Compound 3 gave a limit, no number; the forecaster's own chance of this, stated with the estimate: 85%; the middle value is on the limit's open side.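

Compound 3, like compound 2 and compound 1, reads only as a limit in this assay, so no step among these three compounds can be read. The compounds shown leave open whether chloro, bromo or hydrogen on this aromatic carbon makes any difference to inhibition: the limit of > 20000 nM in this assay, at which 3 of the 3 values shown sit.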